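The source may report more compounds than this note shows. Statements on the series, on what has been measured and on what is new or still open speak of the compounds shown alone.

Compound 1, `O=C(CSC(=S)N[C@H]1CCOC1=O)Nc1ccc(Br)cc1`, in a functional assay on MCF7 cells (Homo sapiens) for cytotoxicity, read by MTT assay, with a stated time of 72 h (on this read-out lower numbers stand for stronger inhibition and higher numbers for weaker inhibition), compound 1 gives 66500 nM. Compound 2, `O=C(CSC(=S)N[C@H]1CCOC1=O)Nc1ccccc1`, in this assay compound 2 reaches only the limit > 128000 nM. Compound 3, `CC(=O)c1ccc(NC(=O)CSC(=S)N[C@H]2CCOC2=O)cc1`, in this assay compound 3 likewise reaches only the limit > 128000 nM.

Compound 3 therefore stands at the limit of the assay, a limit shared by two of the three values shown (the limit of > 128000 nM in this assay, at which 2 of the 3 values shown sit). Compound 4, `O=C(CSC(=S)N[C@H]1CCOC1=O)Nc1ccc(C(=O)/C=C/c2ccc(Br)cc2)cc1`, differs from compound 3 in one place: 2-(4-bromophenyl)ethenyl in place of methyl on a carbonyl carbon. Three measured steps exist, but none of them changes the carbonyl carbon of the acetyl group. The step of an at least 1.9-fold higher number from compound 1 to compound 3 (0.28 log units; that floor lies within the scatter) and the step of an at least 1.9-fold higher number from compound 1 to compound 2 (0.28 log units; that floor lies within the scatter) both run from a number up to the limit, and the step that the two limits leave unreadable from compound 2 to compound 3 runs between two limits. Going by the values given here, they say only that compound 3 is no stronger than compound 1. The group entering compound 4 carries a bromine on an aromatic ring, and compound 1, which also carries bromo on an aromatic carbon, gives 66500 nM. On that slender basis compound 4 is expected to fall below the limit of compound 3, by an estimated step of an at least 5.1-fold lower number from compound 3 to compound 4 (0.70 log units; beyond the scatter). Compound 4 is estimated at 25000 nM, within a range of 5000 nM to 128000 nM.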

Compound 4, half-maximal inhibitory concentration: 18700 nM
Compound 4: the middle estimate sits 1.3-fold (0.13 log units) above what was measured; the measured number falls inside the stated range.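

In this assay, this result shows that the carbonyl carbon whose other neighbour is an aromatic carbon tolerates a much larger group, and that replacing methyl with 2-(4-bromophenyl)ethenyl there gives a readable change: an at least 6.8-fold lower number from compound 3 to compound 4 (0.83 log units; beyond the scatter). The earlier steps, all on an aromatic carbon, gave only a floor within the scatter or could not be read, so this is the first step shown to lie beyond the scatter. Compound 3 has only a limit rather than a number, so the printed size is a floor and not the full size of the change: the limit of > 128000 nM in this assay, at which 2 of the 4 values shown sit.

The change brings in a bromine, an aromatic ring and a double bond together, so the compounds shown do not tell which of these parts matters, and a 2-phenylethenyl group or a saturated 2-(4-bromophenyl)ethyl chain on the same carbonyl carbon would be needed to separate them. As far as these compounds go, it also remains open how this position would respond to an amine or a carboxylic acid on the entering ring.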